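The source may hold more compounds than are shown below. What is called first, only, known or untested is meant among the compounds shown, and "the series" means these compounds.

Compound 1 `O=C1N=C(N2CCC[C@H]2C(=O)Nc2ccc3ncnc(Nc4cccc(Cl)c4)c3c2)S/C1=C/c1ccccc1F` gives 18200 nM in a functional assay on HepG2 cells (Homo sapiens) for antiproliferative activity, read by MTT assay; on this read-out lower numbers stand for stronger inhibition and higher numbers for weaker inhibition. Compound 2 `O=C1N=C(N2CCC[C@H]2C(=O)Nc2ccc3ncnc(Nc4cccc(Cl)c4)c3c2)S/C1=C/c1cccc(Br)n1` gives 2700 nM in this assay, so compound 1 stands highest of the two numbers shown, with a 6.7-fold lower number from compound 1 to compound 2 (0.83 log units; beyond the scatter) as the only measured step in the series. Compound 3 `O=C1N=C(N2CCC[C@H]2C(=O)Nc2ccc3ncnc(Nc4cccc(Cl)c4)c3c2)S/C1=C/c1ccccc1Br` differs from compound 1 by bromo in place of fluoro on an aromatic carbon, placed on an aromatic carbon of a six-membered aromatic ring of carbon only, ortho to a large group. For the measured compounds named here, the one measured step changes the whole ring, 6-bromopyridin-2-yl in place of 2-fluorophenyl, and so bears on the present change only loosely, through the bromine that enters in both cases. Going by the values given here, no measured pair isolates bromo in place of fluoro. The expected step is therefore a 1.8-fold lower number from compound 1 to compound 3 (0.26 log units; within the scatter), a small lowering. Compound 3 is estimated at 10000 nM, within 3500 nM to 28000 nM, in this assay.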

Compound 3, half-maximal inhibitory concentration: 24300 nM
Compound 3: middle estimate off by 2.4-fold (0.39 log units), on the low side, and the stated range covers the measured number.
By their numbers in this assay, from the lowest: compound 2; then compounds 1 and 3 (each within the scatter of the next).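

In this assay, bromo in place of fluoro on this aromatic carbon, ortho to a large group, gives a 1.3-fold higher number from compound 1 to compound 3 (0.13 log units; within the scatter), so this halogen exchange on the ring of carbon only leaves the read-out within the scatter. Entry of bromine alone therefore does not go with a lower number, whereas the change of ring remains beyond the scatter: a 9.0-fold higher number from compound 2 to compound 3 (0.95 log units; beyond the scatter), with 2-bromophenyl in place of 6-bromopyridin-2-yl. No supporting data are available to explain these results.

The compounds shown do not separate the ring nitrogen of 6-bromopyridin-2-yl from the placement of its bromine as the source of that step. Going by these compounds, whether a methoxy group or an amine on the same aromatic carbon would also stay within the scatter remains open.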